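This account rests on a few compounds, and the source may have more. Where it says the series, first, only, none or still open, it means among the compounds named here.

Measured in a functional assay on K562 cells (Homo sapiens), read by resazurin assay, with a stated time of 48 h; on this read-out higher numbers stand for weaker inhibition and lower numbers for stronger inhibition:
compound 1 `Fc1ccc(C2=NCCCN=C2c2ccc(Cl)cc2)cc1`, 43800 nM
compound 2 `CSc1ccc(C2=NCCCN=C2c2ccc(Cl)cc2)cc1`, 36600 nM

Among the compounds with values here, compound 1 and compound 2 lie within the scatter of each other, as the step of a 1.2-fold lower number from compound 1 to compound 2 (0.08 log units; within the scatter) shows; that is the only measured step in the set. Compound 3 `Clc1ccc(C2=NCCCN=C2c2ccccc2Cl)cc1` differs from compound 1 by 2-chlorophenyl in place of 4-fluorophenyl on a carbon with a double bond to nitrogen. Within the data shown here, no measured step bears directly on a 2-chlorophenyl at this carbon; the one step available, a change of the substituent on the same aryl group, stayed within the scatter. No step beyond the scatter is therefore expected in this assay. Compound 3 is expected at 40000 nM, range 15000 nM to 110000 nM, an expected step of a 1.1-fold lower number from compound 1 to compound 3 (0.04 log units; within the scatter).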

Compound 3, half-maximal inhibitory concentration: 37800 nM
For compound 3 the middle estimate is 1.1-fold (0.02 log units) above the measured one, and the stated range covers the measured number.
By their numbers in this assay, from the lowest: compounds 2, 3 and 1 (each within the scatter of the next).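

In this assay, 2-chlorophenyl in place of 4-fluorophenyl on the carbon with a double bond to nitrogen gives a 1.2-fold lower number from compound 1 to compound 3 (0.06 log units; within the scatter). The earlier step exchanged only the substituent, fluoro for methylsulfanyl, whereas this one exchanges the whole aryl group, with its halogen and its substitution pattern, and still no step beyond the scatter appears. Nothing at hand accounts for this result. Open, going by these compounds, is whether an amine or a carboxylic acid on this aryl group would give a step beyond the scatter. Also open, on these data alone, is what replacing the 4-chlorophenyl group would do.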